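The source may hold more compounds than are shown below. What is called first, only, known or untested is meant among the compounds shown, and "the series" means these compounds.

Measured so far in an ADME assay on Vero cells (Chlorocebus sabaeus) for cytotoxicity; a lower number here means that less compound is tolerated, a higher number that more compound is tolerated:
- compound 1 `COc1ccc(-c2nc3c(C(=O)Nc4ccccc4F)cccc3[nH]2)cc1OC`: 24.5 uM
- compound 2 `COc1ccc(-c2nc3c(C(=O)Nc4cnc(Cl)cn4)cccc3[nH]2)cc1OC`: 78.3 uM

Among the measured compounds shown here, compound 1 stands lowest of the two numbers, meaning less of it is tolerated; the only measured step, a 3.2-fold higher number from compound 1 to compound 2 (0.50 log units; beyond the scatter), swaps the aryl group on the amide-type nitrogen. Compound 3 `COc1ccc(-c2nc3c(C(=O)Nc4ccccc4F)cccc3[nH]2)c(OC)c1OC` instead differs from compound 1 by methoxy in place of hydrogen on an aromatic carbon, a methoxy in place of hydrogen on an aromatic carbon. For the measured compounds named here, no measured step touches that ring, so nothing here points in either direction, and a step no larger than the scatter is expected. Compound 3 is therefore estimated at 25 uM, within 10 uM to 60 uM, which means a 1.0-fold higher number from compound 1 to compound 3 (0.01 log units; within the scatter).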

Compound 3, half-maximal toxic concentration: 37.8 uM
Estimate against measurement, compound 3: 1.5-fold (0.18 log units) below, within the range that was stated.
By their numbers in this assay, from the lowest: compounds 1 and 3 (each within the scatter of the next); then compound 2.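

In this assay, methoxy in place of hydrogen on this aromatic carbon, ortho to a large group and to a methoxy group, gives a 1.5-fold higher number from compound 1 to compound 3 (0.19 log units; within the scatter). This position therefore accepts a methoxy group with no change that stands clear of the scatter, at least on the core of compound 1. Nothing available explains this result. Still open, on these data alone, is whether an amine or a carboxylic acid on this same carbon would leave the number just as unchanged. Also open, as far as these compounds go, is whether methoxy here would act alike with the 5-chloropyrazin-2-yl group on the amide-type nitrogen.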